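A few compounds are considered here, and "the series" means these few. Any claim that something is new, unique, unknown or untested is made for them only; others in the source may bear on it.

Compound 1 `CCOc1ccccc1-c1ccc(-c2nc(NC(C)C(=O)O)c3ccncc3n2)cc1`: 2.1
Compound 2 `CCCCC(Nc1c(C#N)c(-c2ccc(-c3ccccc3OCC)cc2)nc2cnccc12)C(N)=O`: 3.6
Compound 3 `CC[C@@H](Nc1c(C#N)c(-c2ccc(-c3ccccc3CO)cc2)nc2cnccc12)C(N)=O`: 2.1

In a physicochemical assay for lipophilicity, read by HPLC, at pH 7.5 (on this read-out higher numbers stand for higher lipophilicity and lower numbers for lower lipophilicity), compound 3 gives 2.1, level with compound 1 at the digits shown, and together these two are the lowest of the three numbers, while compound 2 stands higher by an amount beyond the scatter. Compound 4 `CC[C@@H](Nc1c(C#N)c(-c2ccc(-c3ccccc3C(F)(F)F)cc2)nc2cnccc12)C(N)=O` has not yet been measured. It differs from compound 3 in one place: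

trifluoromethyl in place of hydroxymethyl on an aromatic carbon

Within the data shown here, no measured pair shows this same change, so there is no step to copy. Still, the expected step from compound 3 to compound 4 in this assay is a number 1.40 log units higher from compound 3 to compound 4 (beyond the scatter), a rise well beyond the scatter. Compound 4 is therefore estimated at 3.5, with a likely range from 2.9 to 4.1.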

Compound 4, distribution coefficient: 3.1
The estimate for compound 4 lay 0.40 log units above the measured number; the measured number falls inside the stated range.
By their numbers in this assay, from the lowest: compounds 1 and 3 (each within the scatter of the next); then compound 4; then compound 2.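

In this assay, trifluoromethyl in place of hydroxymethyl gives a number 1.00 log units higher from compound 3 to compound 4 (beyond the scatter) with nothing else in the structure changed. This is the first one-place step among these compounds, and it shows that the group on this aromatic carbon can by itself move the reading beyond the scatter. Nothing shown here accounts for the size of this step.

As far as these compounds go, how an amine or a methoxy group on this same carbon would read remains open. So does whether this change would give a similar step on the core of compound 1.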